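Methoxy to 2-chlorophenyl on a fused pyrazole core

The source may hold more compounds than are shown below. What is called first, only, known or untested is meant among the compounds shown, and "the series" means these compounds.

Measured compounds, in a functional assay on HCT-116 cells (Homo sapiens) for antiproliferative activity, read by MTT assay, with a stated time of 68 h; a lower number here means a stronger inhibitor, a higher number a weaker inhibitor:
- compound 1 `O=S(=O)(Nc1ccc(F)c(C#Cc2cnc3[nH]ncc3c2)c1F)c1cccc(F)c1`: > 10000 nM, a limit of the assay, not a number
- compound 2 `O=S(=O)(Nc1ccc(F)c(C#Cc2cnc3[nH]ncc3c2)c1F)c1ccccn1`: > 10000 nM, a limit of the assay, not a number
- compound 3 `COc1n[nH]c2ncc(C#Cc3c(F)ccc(NS(=O)(=O)c4cccnc4)c3F)cc12`: 1280 nM

Compound 3 is the only one of the three to give an actual number in this assay; the two others sit at the limit (the limit of > 10000 nM in this assay, at which 2 of the 3 values shown sit). For the measured compounds named here, the one single-point step among the measured compounds, a step that the two limits leave unreadable from compound 1 to compound 2, cannot be sized, and it concerns the sulfonyl aryl group, not the part of the molecule that changes here.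

Compound 4 `O=S(=O)(Nc1ccc(F)c(C#Cc2cnc3[nH]nc(-c4ccccc4Cl)c3c2)c1F)c1cccnc1` differs from compound 3 in 2-chlorophenyl in place of methoxy on an aromatic carbon. Going by the values given here, no measured step bears on this change, so its size and direction in this assay are open. With nothing to read from, compound 4 is expected to stay close to compound 3, a step of a 1.3-fold lower number from compound 3 to compound 4 (0.11 log units; within the scatter). The estimate for compound 4 in this assay is therefore 1000 nM, with a wide range from 150 nM to 7000 nM that reflects the absence of any comparable measured step.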

Compound 4, half-maximal inhibitory concentration: > 10000 nM
Compound 4: no number, only a limit; the forecaster's own chance of this, stated with the estimate: 20%; middle value at least 10-fold (1.00 log units) from the limit.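

In this assay, for the compounds shown here, 2-chlorophenyl in place of methoxy on this aromatic carbon gives the only readable step at this position: an at least 7.8-fold higher number from compound 3 to compound 4 (0.89 log units; beyond the scatter). Compound 4 gives > 10000 nM, which is a limit and not a number, so the full size of the loss cannot be read. Compound 3 therefore remains the only compound with an actual number: the limit of > 10000 nM in this assay, at which 3 of the 4 values shown sit.

The compounds shown leave open whether the loss follows from the added ring, from the chlorine or from the removal of methoxy, which a plain phenyl or an amine on this carbon would help to separate. Compound 1 and compound 2 carry different sulfonyl aryl groups from compound 3, so the effect of leaving this carbon without a substituent also remains unread.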